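Adding a hydroxy to the benzyl arm of compound 3

A few compounds are considered here, and "the series" means these few. Any claim that something is new, unique, unknown or untested is made for them only; others in the source may bear on it.

Compound 1 `COc1cccc(-c2c(C)n(Cc3ccccc3F)c3nc(C(C)(C)C)c(CN(C)Cc4ccccc4)n3c2=O)c1`: 72 nM
Compound 2 `COC(=O)C(C)(C)c1nc2n(Cc3ccccc3F)c(C)c(-c3cccc(OC)c3)c(=O)n2c1CN(C)Cc1ccccn1`: 4.2 nM
Compound 3 `COC(=O)C(C)(C)c1nc2n(Cc3ccccc3F)c(C)c(-c3cccc(OC)c3)c(=O)n2c1CN(C)Cc1ccccc1`: 59 nM

In an assay on isolated protein for binding affinity to Gonadotropin-releasing hormone receptor (Homo sapiens) (on this read-out higher numbers stand for weaker inhibition and lower numbers for stronger inhibition), compound 3 gives 59 nM, the second highest of the three numbers. Compound 1 sits nearest, with a 1.2-fold lower number from compound 1 to compound 3 (0.09 log units; within the scatter), while compound 2 lies furthest, with a 14-fold higher number from compound 2 to compound 3 (1.15 log units; beyond the scatter). Compound 4 `COC(=O)C(C)(C)c1nc2n(Cc3ccccc3F)c(C)c(-c3cccc(OC)c3)c(=O)n2c1CN(C)Cc1ccccc1O` differs from compound 3 by hydroxy in place of hydrogen on an aromatic carbon, on an aromatic carbon of a six-membered aromatic ring of carbon only, ortho to a large group. Among the compounds with values here, no measured step touches this position, so nothing measured bears directly on it; the one large step, from a phenyl to a pyridin-2-yl at the same arm, changed a different atom. In this assay compound 4 is therefore expected at 40 nM, within 10 nM to 160 nM, a step of a 1.5-fold lower number from compound 3 to compound 4 (0.17 log units; within the scatter) that is estimated to stay within the scatter.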

Compound 4, inhibition constant: 490 nM
Estimate against measurement, compound 4: 12-fold (1.09 log units) below, outside the stated range (above it).
By their numbers in this assay, from the lowest: compound 2; then compounds 3 and 1 (each within the scatter of the next); then compound 4.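

In this assay, the ring of the benzyl arm proves sensitive to even one added oxygen: hydroxy in place of hydrogen, ortho to a large group, gives an 8.3-fold higher number from compound 3 to compound 4 (0.92 log units; beyond the scatter) and shows that this position does not accept the change freely. Against the pyridin-2-yl arm, 2-hydroxyphenyl gives a 120-fold higher number from compound 2 to compound 4 (2.07 log units; beyond the scatter), so among these three arms the ring can move the number in either direction. No measurement at hand explains the rise. Going by these compounds, what an amino group or a carboxylic acid would do at this same place remains open.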